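Swapping Phenyl for Furan on a Fused Core

The compounds below may be only part of what the source reports. "The series", "measured", "known", "first", "only" and "open" are said of these compounds alone.

Measured so far:
Compound 1, `COC(=O)CN1C(=O)c2ccccc2NC1c1ccco1`, gives 44 nM in an assay on mitochondria for inhibition of Amine oxidase [flavin-containing] A (Bos taurus), read by fluorescence, with a stated time of 60 min; a higher number here means a weaker inhibitor, a lower number a stronger inhibitor.
Compound 2, `NNC(=O)CCCN1C(=O)c2ccccc2NC1c1ccccc1`, gives 47 nM in this assay.

Of the compounds shown here, two share a fused core and have been measured in this assay. Compound 2 holds the higher of the two numbers, but its nearest neighbour is compound 1, whose number lies within the usual scatter, so the two values show no real separation. For the measured compounds named here, compound 1 and compound 2 differ in two places at once, so no single step connects them; their values simply sit side by side.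

Compound 3, `NNC(=O)CCCN1C(=O)c2ccccc2NC1c1ccco1`, has not yet been measured. It differs from compound 2 in one place: furan-2-yl in place of phenyl on a saturated ring carbon. The same furan-2-yl group sits on the corresponding carbon of compound 1, which gives 44 nM, a value within the scatter of compound 2. On that basis a step of no size beyond the scatter is expected in this assay, in either direction. Compound 3 is therefore estimated at 45 nM, within a range from 20 nM to 100 nM, meaning an expected step of a 1.0-fold lower number from compound 2 to compound 3 (0.02 log units; within the scatter).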

Compound 3, half-maximal inhibitory concentration: 36 nM
Estimate against measurement, compound 3: 1.3-fold (0.10 log units) above; low and high end bracket the measured number.
By their numbers in this assay, from the lowest: compounds 3, 1 and 2 (each within the scatter of the next).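

In this assay furan-2-yl in place of phenyl on the saturated ring carbon gives a 1.3-fold lower number from compound 2 to compound 3 (0.12 log units; within the scatter) and so leaves the two compounds without real separation, which shows that this position takes either a six-membered carbon ring or a five-membered ring with one oxygen without a readable difference, something the earlier pair, differing in two places at once, could not show. With furan-2-yl held fixed, the chain bound to the amide-type nitrogen can now be read on its own: 2-(aminocarbamoyl)ethyl in place of methoxycarbonyl gives a 1.2-fold lower number from compound 1 to compound 3 (0.09 log units; within the scatter) and again stays without real separation. No measurement at hand offers an explanation for either result.

As far as these compounds go, whether any group on the saturated ring carbon would move the number beyond the scatter stays open, for example cyclohexyl, a pyridine ring or a phenyl ring bearing a chlorine. The same question stands for the chain, where a carboxylic acid, an amine or a longer chain might give a different answer from the ends seen so far.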